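The source may hold more compounds than are shown below. What is called first, only, known or untested is meant among the compounds shown, and "the series" means these compounds.

Working notes on the series.

Compound 1 `Cc1ccccc1-c1cccc(COc2ccc([C@H](CC(=O)O)c3nccn3C)cc2)c1` and compound 2 `Cc1cc(F)ccc1-c1cccc(COc2ccc([C@H](CC(=O)O)c3nccn3C)cc2)c1` share one core and differ only at the biaryl end. In an assay on CHO cells for agonist activity at Free fatty acid receptor 1 (Homo sapiens), read by luminescence, with a stated time of 20 s, in the presence of a further agent that is not named here (a higher number here means that more compound is needed for the effect, a lower number that less compound is needed), compound 1 gives 89000 nM, and compound 2 gives 21000 nM. Among the compounds with values here, the step of a 4.2-fold lower number from compound 1 to compound 2 (0.63 log units; beyond the scatter) is the only measured step, and it places compound 2 at the lowest of the two numbers, with compound 1 as its only neighbour.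

Compound 3 `Cc1cccc(C)c1-c1cccc(COc2ccc([C@H](CC(=O)O)c3nccn3C)cc2)c1` is not yet measured. It differs from compound 2 in one place: 2,6-dimethylphenyl in place of 4-fluoro-2-methylphenyl on an aromatic carbon. Two things happen at once. The fluorine that separates compound 1 from compound 2 is gone again, which the measured step of a 4.2-fold lower number from compound 1 to compound 2 (0.63 log units; beyond the scatter) suggests should push the number back up toward that of compound 1. Within the data shown here, the second methyl that enters has no measured counterpart in this set; nothing here shows what it does. Among the measured compounds shown here, the one measured step therefore argues for a rise, of moderate size, with the added methyl an open question.

Compound 3 is estimated in this assay at 60000 nM, between 15000 nM and 200000 nM. This corresponds to an expected step of a 2.9-fold higher number from compound 2 to compound 3 (0.46 log units; beyond the scatter), resting on the measured step of a 4.2-fold lower number from compound 1 to compound 2 (0.63 log units; beyond the scatter) alone.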

Compound 3, half-maximal effective concentration: 29000 nM
The estimate for compound 3 lay 2.1-fold (0.32 log units) above the measured number, within the range that was stated.
By their numbers in this assay, from the lowest: compounds 2 and 3 (each within the scatter of the next); then compound 1.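

In this assay, within the data shown here, a 3.1-fold lower number from compound 1 to compound 3 (0.49 log units; beyond the scatter) shows that an added methyl on the terminal ring also has a measurable effect, so the fluoro of compound 2 is no longer the only change at this end of the molecule seen to lower the number from that of compound 1. The exchange of 4-fluoro-2-methylphenyl for 2,6-dimethylphenyl, a 1.4-fold higher number from compound 2 to compound 3 (0.14 log units; within the scatter), lies within the scatter, so this assay does not separate compound 2 from compound 3, and removing the fluoro does not return the number to that of compound 1 when the second methyl enters. The data available here offer no independent measurement that would explain either step.

As far as these compounds go, it remains open whether a fluoro and a second methyl on the same ring would combine to give a lower number than either does alone. From the compounds shown here alone, it is also open whether a larger or different group at this place, such as chloro, methoxy or trifluoromethyl, would lower the number further, and how far any such step would carry over to other changes on the shared core.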